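Swapping methyl for fluoro on an inactive thyroid receptor series

The source may report more compounds than this note shows. Statements on the series, on what has been measured and on what is new or still open speak of the compounds shown alone.

Compound 1 `CN(CC(=O)N1CCN(c2ccccc2)CC1)C(=O)c1ccc(S(C)(=O)=O)c([N+](=O)[O-])c1` gives > 60000 nM in an assay on isolated protein for inhibition of thyroid hormone receptor beta (Homo sapiens), read by fluorescence polarization (a lower number here means a stronger inhibitor, a higher number a weaker inhibitor), which is a limit of the assay and not a number.
Compound 2 `Cc1ccc(N2CCN(C(=O)C3CCN(C(=O)c4ccc(S(C)(=O)=O)c([N+](=O)[O-])c4)CC3)CC2)cc1` gives > 60000 nM in this assay, again a limit of the assay.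
Compound 3 `CS(=O)(=O)c1ccc(C(=O)NCCCC(=O)N2Cc3ccccc3C2)cc1[N+](=O)[O-]` gives > 60000 nM in this assay, also a limit of the assay.

Compound 2 therefore stands nowhere in particular among these three: every value shown rests at the limit of > 60000 nM in this assay, at which 3 of the 3 values shown sit, so no ranking between them is possible. Compound 4 `CS(=O)(=O)c1ccc(C(=O)N2CCC(C(=O)N3CCN(c4ccc(F)cc4)CC3)CC2)cc1[N+](=O)[O-]` differs from compound 2 by one atom: fluoro in place of methyl on an aromatic carbon. For the measured compounds named here, with no measured step anywhere in this set, the expectation for the step from compound 2 to compound 4 is none beyond the scatter, and the estimated change is a number no higher from compound 2 to compound 4 (the limit leaves the size open). Compound 4 is expected to sit at 60000 nM, within 20000 nM to 200000 nM, most likely reported again as a limit rather than a number.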

Compound 4, half-maximal inhibitory concentration: > 60000 nM
Compound 4 gave a limit, no number; the forecaster's own chance of this, stated with the estimate: 85%; the middle value sits exactly at the limit.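

No step can be read from compound 2 to compound 4, since both values are limits of the assay and not numbers: the limit of > 60000 nM in this assay, at which 4 of the 4 values shown sit. The compounds shown leave open whether fluoro in place of methyl changes the inhibition at all.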